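The compounds below may be only part of what the source reports. "The series", "measured", "known", "first", "only" and "open" are said of these compounds alone.

Measured compounds:
- compound 1, `COCc1nc2nc(C)cc(Nc3ccc(C(F)(F)F)cc3)n2n1`: 150000 nM
- compound 2, `CCC(F)(F)c1nc2nc(C)cc(Nc3ccc(S(F)(F)(F)(F)F)cc3)n2n1`: 15000 nM
- compound 3, `Cc1cc(Nc2ccc(Cl)cc2)n2nc(C(C)C)nc2n1`: 83000 nM

All three numbers come from a physicochemical assay for solubility, at pH 6.5; on this read-out higher numbers stand for higher solubility and lower numbers for lower solubility. Among them compound 1 stands highest, but its gap to compound 3 lies within the usual scatter, so these two cannot be ordered against each other. Compound 2 lies beyond the scatter on the lower side of compound 1. For the measured compounds named here, no two of the measured compounds differ in a single place, so no step of one change is available from the data as they stand.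

Compound 4, `CSc1nc2nc(C)cc(Nc3ccc(C(F)(F)F)cc3)n2n1`, is not yet measured. It differs from compound 1 in one place: methylsulfanyl in place of methoxymethyl on an aromatic carbon. The change sits on an aromatic carbon of the five-membered aromatic ring, between two ring nitrogen atoms, within the fused system of the shared core.

Going by the values given here, with no measured step of this kind to rest on, a modest downward step is expected, a 2.7-fold lower number from compound 1 to compound 4 (0.44 log units; beyond the scatter), of a size that may or may not clear the scatter. In this assay compound 4 is estimated at 55000 nM, with a range from 20000 nM to 130000 nM.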

Compound 4, solubility: 19000 nM
Compound 4: the middle estimate sits 2.9-fold (0.46 log units) above what was measured; the measured number lies below the stated range.
By their numbers in this assay, from the lowest: compounds 2 and 4 (each within the scatter of the next); then compounds 3 and 1 (each within the scatter of the next).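

In this assay, for the compounds shown here, methylsulfanyl in place of methoxymethyl on an aromatic carbon gives a 7.9-fold lower number from compound 1 to compound 4 (0.90 log units; beyond the scatter) and this is the first single-place step, with the rest of the molecule held constant. It shows that this position, on the five-membered aromatic ring, can move the read-out beyond the scatter even though the entering and leaving groups have the same counts of hydrogen-bond donors and acceptors and differ by only one heavy atom. Nothing measured here accounts for the size of this step.

Still open, on these data alone, is whether the step follows the sulfur atom or the shorter chain, and a methoxy group, a longer ether chain or an amine at this place would bear on that. Also open, as far as these compounds go, is whether the same change gives a similar step when the trifluoromethyl group of compound 1 is replaced by another group.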